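Fluoro Added Beside Bromo on the Pendant Phenyl

The source may report more compounds than this note shows. Statements on the series, on what has been measured and on what is new or still open speak of the compounds shown alone.

Compound 1 `CCNC(=O)c1cc(Oc2ccc(NC(=O)c3cc4cccnc4n(-c4ccccc4)c3=O)cc2)ccn1`: 2650 nM
Compound 2 `CCNC(=O)c1cc(Oc2ccc(NC(=O)c3cc4cccnc4n(-c4ccc(Br)cc4)c3=O)cc2)ccn1`: "not determined" (no result reported)

The series shares one core, carried through all three compounds, and differs only in the phenyl ring attached at the nitrogen of that core. In a functional assay on U-87MG ATCC cells for antiproliferative activity against U-87 MG (Homo sapiens), read by MTT assay, with a stated time of 72 h (a lower number here means a stronger inhibitor, a higher number a weaker inhibitor), compound 1 gives 2650 nM. Compound 2 carries a bromo group on that phenyl ring, but in this assay compound 2 gives "not determined" (no result reported), so it stands without a number of its own, and nothing can be said of how the bromo group alters the value seen for compound 1.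

Compound 3 `CCNC(=O)c1cc(Oc2ccc(NC(=O)c3cc4cccnc4n(-c4ccc(Br)cc4F)c3=O)cc2)ccn1` takes the next step from compound 2: fluoro in place of hydrogen on an aromatic carbon. Among the compounds with values here, with no measured step between two compounds here, there is no basis in the data for a change of any size or direction beyond the scatter. Within the data shown here, the only anchor is compound 1. Compound 3 is therefore expected to lie near the value of compound 1, at an estimated 2500 nM, within a wide range from 700 nM to 9000 nM.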

Compound 3, half-maximal inhibitory concentration: 10300 nM
Compound 3: the middle estimate sits 4.1-fold (0.61 log units) below what was measured; the measured number lies above the stated range.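

Putting 4-bromo-2-fluorophenyl in place of phenyl on the aromatic nitrogen of the shared core gives, in this assay, a 3.9-fold higher number from compound 1 to compound 3 (0.59 log units; beyond the scatter), a modest move toward a weaker inhibitor and the first measured sign that a change on this pendant ring can shift the number beyond the usual scatter. The step from compound 2 to compound 3 cannot be read, as compound 2 has no number, so the move cannot be divided between the bromo group and the fluoro group. Nothing measured here accounts for the loss in activity.

Open, then, is whether the fluoro group alone, on a phenyl ring without the bromo group, would raise the number, or whether the bromo group carries most of the step. Also open, as far as these compounds go, is how this position would respond to a group of another kind in place of the bromo group, such as chloro, methoxy, an amine or a carboxylic acid.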